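Aryl-piperazine amides of a shared core: estimate for compound 4

A few compounds are considered here, and "the series" means these few. Any claim that something is new, unique, unknown or untested is made for them only; others in the source may bear on it.

Measured so far in a functional assay (MiaPaCa cells, Homo sapiens) for inhibition, read by sulforhodamine B assay, with a stated time of 48 h; on this read-out higher numbers stand for weaker inhibition of growth and lower numbers for stronger inhibition of growth:
compound 1, `O=C(CCN1C(=O)CSc2ccccc21)N1CCN(c2ccc(F)cc2)CC1`: > 100000 nM
compound 2, `O=C(CCN1C(=O)CSc2ccccc21)N1CCN(c2ccccc2F)CC1`: > 100000 nM
compound 3, `COc1ccccc1N1CCN(CCCNC(=O)CCN2C(=O)CSc3ccccc32)CC1`: 59200 nM

Compound 1 reaches only a limit of this assay, > 100000 nM. Compound 2 likewise reaches only a limit, > 100000 nM. The step that the two limits leave unreadable from compound 1 to compound 2 therefore cannot be read; both ends sit at the limit of > 100000 nM in this assay, at which 2 of the 3 values shown sit. For the measured compounds named here, compound 3 is the sole compound of the three with a number, 59200 nM. It therefore stands alone and cannot be ranked against compound 1 or compound 2.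

Compound 4, `O=C(CCN1C(=O)CSc2ccccc21)NCCCN1CCN(c2ccccc2F)CC1`, keeps the three-carbon linker of compound 3 and differs from it by fluoro in place of methoxy on an aromatic carbon. Going by the values given here, no measured step covers this exchange: the only step between measured compounds, from compound 1 to compound 2, moves a fluoro from one ring position to another and is unreadable, and no pair compares a methoxy with a fluoro. Nothing measured therefore points to a step beyond the scatter.

For compound 4 the expectation is a value close to that of compound 3, with the step of a 1.2-fold higher number from compound 3 to compound 4 (0.07 log units; within the scatter) expected to fall within the scatter. The estimate for compound 4 in this assay is 70000 nM, ranging from 30000 nM to 160000 nM, with a fair chance that only a limit is reported.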

Compound 4, concentration for 50% growth inhibition: > 100000 nM
Compound 4: a limit, no number; the forecaster's own chance of this, stated with the estimate: 35%; at least 1.4-fold (0.15 log units) between middle value and limit.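

For the compounds shown here, the exchange of methoxy for fluoro on an aromatic carbon, ortho to a large group, gives the first step at this position in this assay that has any readable size: an at least 1.6-fold higher number from compound 3 to compound 4 (0.22 log units; that floor lies within the scatter). Compound 4 stands at a limit, so this is a floor and not a measured size, and that floor alone does not separate the two compounds beyond the scatter. With the three-carbon linker kept, the 2-fluorophenyl group gives no number in this series, and the only number stays with the 2-methoxyphenyl group of compound 3, at the weak end of the read-out and in a set that mostly reaches the limit: the limit of > 100000 nM in this assay, at which 3 of the 4 values shown sit.

As far as these compounds go, how far the true value of compound 4 lies from that of compound 3 remains open, as does whether any methoxy to fluoro effect exists at all on this read-out. Also open, from the compounds shown here alone, is what a chloro, a hydroxyl or an amine would give in the same place on the aromatic ring, and what a longer chain would give in place of the three-carbon linker.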